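The compounds below may be only part of what the source reports. "The series", "measured", "known", "first", "only" and "open" are said of these compounds alone.

Measured compounds:
compound 1, `CSc1cccc(-c2nc(N)nc(N)n2)c1`: 2.16
compound 2, `CCN(CC)c1c(C)n(-c2ccccc2)c(=O)n(C)c1=O`: 2.19

In a physicochemical assay for lipophilicity (a lower number here means a more polar compound, a higher number a more lipophilic compound), compound 1 gives 2.16, the lower of the two numbers, and compound 2 gives 2.19, a value that lies within the scatter of compound 1, so the two compounds show no real difference in this assay. Compound 3, `Nc1nc(N)nc(-c2cccc(Br)c2)n1`, has not yet been measured. It differs from compound 1 in one place: bromo in place of methylsulfanyl on an aromatic carbon. The bromo group enters on an aromatic carbon of a six-membered aromatic ring of carbon only. Within the data shown here, no pair of measured compounds differing in one place is available to anchor the size of such a step, so the expectation rests on the change alone. A small rise in this assay is expected, a step of about a number 0.24 log units higher from compound 1 to compound 3 (within the scatter), which may not exceed the scatter. Compound 3 is therefore expected to give 2.4, with a range from 2.1 to 2.7.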

Compound 3, partition coefficient: 2.44
Beside the measured number, compound 3's estimate is 0.04 log units below it, within the range that was stated.
By their numbers in this assay, from the lowest: compounds 1, 2 and 3 (each within the scatter of the next).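

Among these compounds, compound 3 gives the first step that can be read: in this assay, bromo in place of methylsulfanyl on an aromatic carbon, meta to a group of 8 heavy atoms, comes to a number 0.28 log units higher from compound 1 to compound 3 (within the scatter) and no more. At this position, then, a group of 2 heavy atoms that counts a hydrogen-bond acceptor can give way to a single bromine that counts none, and the two compounds cannot be told apart in this read-out. No measurement on these compounds speaks to what lies behind this step.

The compounds shown leave open whether an amine, a carboxylic acid or a longer chain at this position would give a step beyond the scatter. They also leave open whether the same exchange gives a step of like size on a different core.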